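The compounds below may be only part of what the source reports. "The series", "measured", "known", "first", "only" and "open" are said of these compounds alone.

Compound 1 `COc1cc(-c2cc(/C=C/C(=O)c3ccc(N)cc3)[nH]n2)cc(OC)c1OC` and compound 2 `COc1ccc(-c2cc(/C=C/C(=O)c3ccc(OC)c(OC)c3)[nH]n2)cc1` have both been tested in a functional assay on A549 cells (Homo sapiens) for cytotoxicity, read by sulforhodamine B assay, with a stated time of 48 h, tested at 100 uM; on this read-out higher numbers stand for a weaker effect at the one concentration tested and lower numbers for a stronger effect. In this assay compound 1 gives -52%, the lowest of the two numbers recorded so far, while compound 2 gives -45%, a number only a little higher and within the usual scatter of this kind of measurement, so the two cannot be told apart on these data. Compound 3 `COc1cc(-c2cc(/C=C/C(=O)c3ccc(Cl)c(Cl)c3)[nH]n2)cc(OC)c1OC` has not yet been measured. It differs from compound 1 in a single place: 3,4-dichlorophenyl in place of 4-aminophenyl on a carbonyl carbon. Within the data shown here, no pair of measured compounds shows what such a change does in this assay, so there is no earlier step to compare it with, and any expectation rests on the value of compound 1 alone. For compound 3 a step of a number 8 percentage points lower from compound 1 to compound 3 (within the scatter) is expected, a modest move toward the lower, stronger end that may well stay within the scatter. Compound 3 is therefore estimated to give -60% in this assay, with a range from -85% to -30%.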

Compound 3, a percentage reported as activity, at one concentration (the size of the read-out at that concentration, not a potency): 2%
Estimate against measurement, compound 3: 62 percentage points below; measured number outside the range, above it.
By their numbers in this assay, from the lowest: compounds 1 and 2 (each within the scatter of the next); then compound 3.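

Among these compounds, this is the first measured look at how much the group on the carbonyl carbon matters in this assay and the answer is clear: replacing 4-aminophenyl with 3,4-dichlorophenyl gives a number 54 percentage points higher from compound 1 to compound 3 (beyond the scatter) and so moves the result toward the weak end of the scale. With the rest of the molecule unchanged, compound 3 gives 2% in this test at a single concentration, so the strong effect seen for compound 1 depends on what sits at this place and does not come from the shared core alone. No measurement shown gives a reason for this step.

The change removes the amino group and adds two chlorine atoms in one move, so the compounds shown leave open which of these two differences accounts for the step. A ring with a single chlorine, or with a hydroxyl group where compound 1 has its amino group, would help to separate the two, and a measured series of this kind would show whether the amino group itself is needed for the strong effect.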